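A chloro for methyl swap in a cytotoxicity series

This account rests on a few compounds, and the source may have more. Where it says the series, first, only, none or still open, it means among the compounds named here.

Three compounds have been measured in an ADME assay on Vero cells (Chlorocebus sabaeus) for cytotoxicity, read by neutral red uptake, tested at 197 ug/mL; a higher number here means a weaker effect of the compound at the concentration tested, a lower number a stronger effect:

Compound 1 `O=C1CSC(c2cccc(O)c2)N1CCN1CCCCC1` gives 100%.
Compound 2 `Cc1ccc(C2SCC(=O)N2CCN2CCCCC2)cc1` gives 85%.
Compound 3 `COc1cccc(C2SCC(=O)N2CCN2CCCCC2)c1` gives 66%.

Compound 2 stands second highest of the three in this assay: compound 1 sits above it, with a step of a number 15 percentage points lower from compound 1 to compound 2 (beyond the scatter) between them, and compound 3 sits below it, the two values differing beyond the scatter. Within the data shown here, the only other measured step is a number 34 percentage points lower from compound 1 to compound 3 (beyond the scatter). Compound 4 `O=C1CSC(c2ccc(Cl)cc2)N1CCN1CCCCC1` differs from compound 2 by chloro in place of methyl on an aromatic carbon. Neither measured step bears directly on this kind of change: one exchanges the whole group on a saturated ring carbon, the other puts a methyl in place of hydrogen on an oxygen, and neither puts a chloro in place of a methyl on an aromatic carbon. Among the measured compounds shown here, the known steps in this assay run from modest to large, so movement is possible, but no measured pair points in a direction. The step is therefore estimated to be a number 5 percentage points lower from compound 2 to compound 4 (within the scatter), within the scatter. The expected value for compound 4 in this assay is 80%, in a range from 55% to 100%.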

Compound 4, a percentage reported as activity, at one concentration (the size of the read-out at that concentration, not a potency): 68%
Compound 4: middle estimate off by 12 percentage points, on the high side; the range from low to high includes it.
By their numbers in this assay, from the lowest: compounds 3 and 4 (each within the scatter of the next); then compound 2; then compound 1.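

The swap of 4-methylphenyl to 4-chlorophenyl is the first change shown at this aromatic carbon, and in this assay it gives a number 17 percentage points lower from compound 2 to compound 4 (beyond the scatter), so exchanging one heavy atom here, with no change in the count of hydrogen-bond donors or acceptors, is enough to shift the read-out towards a stronger effect. Measured against the 3-hydroxyphenyl group, the 4-chlorophenyl group gives a number 32 percentage points lower from compound 1 to compound 4 (beyond the scatter), a step that the earlier compounds could not have shown for this group. No measurement to hand explains why the chloro and methyl groups differ here.

From the compounds shown here alone, what stays open is whether this shift is particular to chloro, since a fluoro, a nitrile or a carboxylic acid on the same aromatic carbon could read differently. Going by these compounds, it is also open whether a longer chain or an amine there would carry the number further in the same direction.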